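The source may report more compounds than this note shows. Statements on the series, on what has been measured and on what is new or still open speak of the compounds shown alone.

Within the data shown here, compound 3 `COc1cc2c(cc1N1C[C@H](C)NC(C)(C)C1)N(S(=O)(=O)c1ccc(-c3ccccn3)s1)CC2` gives 0.794 nM in a functional assay for agonist activity at growth hormone secretagogue receptor type 1 (Homo sapiens), read by FLIPR (on this read-out lower numbers stand for an effect already at smaller amounts and higher numbers for an effect only at larger amounts of compound), the second highest of the three numbers measured so far: compound 1 `COc1cc2c(cc1N1C[C@@H](C)N[C@@H](C)C1)N(S(=O)(=O)c1ccc(-c3ccccn3)s1)CC2` gives 0.159 nM, while compound 2 `COc1cc2c(cc1N1CCNCC1)N(S(=O)(=O)c1ccc(-c3ccccn3)s1)CC2` gives 63.1 nM. Compound 4 `COc1cc2c(cc1N1CCNC(C)(C)C1)N(S(=O)(=O)c1ccc(-c3ccccn3)s1)CC2` differs from compound 3 by hydrogen in place of methyl on a saturated ring carbon. Among the measured compounds shown here, three steps bear on this change. Removing both methyl groups gave a 400-fold higher number from compound 1 to compound 2 (2.60 log units; beyond the scatter), whereas a 5.0-fold higher number from compound 1 to compound 3 (0.70 log units; beyond the scatter) and a 79-fold lower number from compound 2 to compound 3 (1.90 log units; beyond the scatter) show that a partially methylated ring keeps most of the low number. Taking one methyl away from compound 3 is therefore expected to move the number part of the way toward compound 2, a step of a 10-fold higher number from compound 3 to compound 4 (1.00 log units; beyond the scatter). For compound 4 the estimate is 8 nM, expected to lie between 2 nM and 40 nM.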

Compound 4, half-maximal effective concentration: 15.9 nM
Compound 4: middle estimate off by 2.0-fold (0.30 log units), on the low side, within the range that was stated.
By their numbers in this assay, from the lowest: compound 1; then compound 3; then compound 4; then compound 2.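

The methyl on this saturated ring carbon counts for much on its own (a 20-fold higher number from compound 3 to compound 4 (1.30 log units; beyond the scatter)), a large step beside the modest one that 3,3-dimethylpiperazin-1-yl gives over piperazin-1-yl (a 4.0-fold lower number from compound 2 to compound 4 (0.60 log units; beyond the scatter)). The count of methyl groups alone does not settle the number either, since 3,3-dimethylpiperazin-1-yl and 3,5-dimethylpiperazin-1-yl stand far apart (a 100-fold higher number from compound 1 to compound 4 (2.00 log units; beyond the scatter)). Nothing available explains these steps. As far as these compounds go, whether ethyl or hydroxymethyl on this ring carbon would hold the low number remains open, as does the effect of a methyl group on the ring nitrogen.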